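This account rests on a few compounds, and the source may have more. Where it says the series, first, only, none or still open, it means among the compounds named here.

Measured so far:
- compound 1, `O=C(Nc1cccc(-n2cc(-c3ccncc3)c(-c3ccc(Cl)c(O)c3)n2)c1)Nc1cccc(C(F)(F)F)c1` — in a functional assay on NCI/ADR-RES cells (Homo sapiens) for inhibition, read by sulforhodamine B assay, with a stated time of 48 h (a higher number here means a weaker inhibitor of growth, a lower number a stronger inhibitor of growth), compound 1 gives only a limit, > 32500 nM.
- compound 2, `COc1cc(-c2nn(-c3cccc(NC(=O)Nc4cc(C(F)(F)F)cc(C(F)(F)F)c4)c3)cc2-c2ccncc2)ccc1Cl` — in this assay compound 2 gives 5180 nM.

Within the data shown here, compound 2 holds the only actual number in this assay; the other entry, for compound 1, is a limit and not a number, as noted in the limit of > 32500 nM in this assay, at which 1 of the 2 values shown sits. Among the measured compounds shown here, no pair of measured compounds differs in one place, so no measured step exists to lean on.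

The next compound, compound 3, `O=C(Nc1cccc(-n2cc(-c3ccncc3)c(-c3ccc(Cl)c(O)c3)n2)c1)Nc1cc(C(F)(F)F)cc(C(F)(F)F)c1`, follows from compound 2 by hydrogen in place of methyl on an oxygen on an aromatic ring. Compound 1 also carries hydroxy on that oxygen, but it differs from compound 3 elsewhere as well, so its limit cannot be read as a direct guide.

For the measured compounds named here, with no measured step of this kind, the expectation for compound 3 is a modest shift toward weaker growth inhibition, a 1.9-fold higher number from compound 2 to compound 3 (0.29 log units; within the scatter), and the risk that this assay returns only a limit is real. The estimate for compound 3 in this assay is 10000 nM, between 3000 nM and 40000 nM.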

Compound 3, concentration for total growth inhibition: 5250 nM
Compound 3: the middle estimate sits 1.9-fold (0.28 log units) above what was measured, within the range that was stated.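

In this assay the swap from 4-chloro-3-methoxyphenyl to 4-chloro-3-hydroxyphenyl now has a measured step of a 1.0-fold higher number from compound 2 to compound 3 (0.01 log units; within the scatter), so this pair does not separate methoxy from hydroxy on this oxygen on an aromatic ring. With hydroxy held in place, trifluoromethyl in place of hydrogen on an aromatic carbon gives an at least 6.1-fold lower number from compound 1 to compound 3 (0.79 log units; beyond the scatter), so of the two single changes shown, only this one moves the read-out beyond the scatter. Compound 1 gives a limit and not a number, so that step has a lower bound but no exact size: the limit of > 32500 nM in this assay, at which 1 of the 3 values shown sits.

Each of these two changes rests on a single pair, so neither reading extends beyond these compounds or to other substituents. Open questions are whether an ethoxy group or a longer alkoxy chain on that oxygen stays level with methoxy and hydroxy, and whether a nitrile or a chlorine on that aromatic carbon can stand in for trifluoromethyl.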